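A few compounds are considered here, and "the series" means these few. Any claim that something is new, unique, unknown or untested is made for them only; others in the source may bear on it.

The measured compounds:

compound 1 `CS/C(=N\C(=O)c1ccno1)NC(=O)c1ccno1` — in a functional assay on K562 cells (Homo sapiens) for cytotoxicity, read by MTT assay, with a stated time of 72 h (on this read-out higher numbers stand for lower toxicity in this test and lower numbers for higher toxicity in this test), compound 1 gives > 100000 nM, which is a limit of this assay and not a number.

compound 2 `CS/C(=N\C(=O)c1csc([N+](=O)[O-])c1)NC(=O)c1csc([N+](=O)[O-])c1` — in this assay compound 2 gives > 100000 nM, again a limit rather than a number.

compound 3 `C[Se]/C(=N\C(=O)c1cc(-c2ccccc2)nc2ccccc12)NC(=O)c1cc(-c2ccccc2)nc2ccccc12` — in this assay compound 3 gives 73100 nM.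

Compound 1 therefore stands at the limit of > 100000 nM in this assay, at which 2 of the 3 values shown sit, so only a limit is known for it; compound 2 sits at the same limit, and only compound 3 yields a number at all.

The unmeasured compound 4 `C[Se]/C(=N\C(=O)c1ccno1)NC(=O)c1ccno1` differs from compound 1 in one place: a group of 2 heavy atoms (1 carbon, 1 selenium; no ring) in place of a group of 2 heavy atoms (1 carbon, 1 sulfur; no ring), on a carbon with a double bond to nitrogen. Within the data shown here, no pair of measured compounds differs in exactly this way, so the size of the step in this assay is not known from the data. Compound 3, which carries the same entering group as compound 4 on a different core, does yield a number, whereas compound 1 does not; beyond that the two values show nothing about the step itself. In this assay the step from compound 1 to compound 4 is expected to be small, with no clear direction, a number no higher from compound 1 to compound 4 (the limit leaves the size open), because compound 1 sits at the limit of > 100000 nM in this assay, at which 2 of the 3 values shown sit.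

For compound 4 in this assay a value of about 100000 nM is estimated, expected to fall between 40000 nM and 300000 nM.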

Compound 4, concentration lethal to 50% of the cells: > 100000 nM
Compound 4: a limit, no number (the forecaster's own chance of this, stated with the estimate: 55%); the middle value lies on the limit itself.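

In this assay compound 4 gives > 100000 nM, which is a limit and not a number. Compound 1 also sits at a limit, so no step between compound 1 and compound 4 can be read: the limit of > 100000 nM in this assay, at which 3 of the 4 values shown sit.

The compounds shown leave open whether putting the selenium-bearing group in place of methylsulfanyl changes this read-out at all.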